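A single methyl on compound 3

The source may hold more compounds than are shown below. What is called first, only, known or untested is meant among the compounds shown, and "the series" means these compounds.

In a functional assay on CCRF-CEM cells (Homo sapiens) for cytotoxicity (a lower number here means that less compound is tolerated, a higher number that more compound is tolerated), compound 1 `Nc1ncnc2c1ncn2[C@H]1C=C[C@@H](CO)O1` gives 96000 nM. Compound 2 `COc1ccc2c(c1)COP(=O)(OC[C@@H]1C=C[C@H](n3cnc4c(N)ncnc43)O1)O2` carries a larger phosphorus-containing group on the core of compound 1. Over repeated entries, compound 2 gives 62000 nM; 40000 nM; 77000 nM (3 entries). Compound 3 `Nc1ncnc2c1ncn2[C@H]1C=C[C@@H](COP2(=O)OCc3ccccc3O2)O1`, built on the same core, gives 86000 nM. That places compound 3 within the scatter of compound 1, while compound 2 has several entries and no single number.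

Compound 4 `Cc1cccc2c1OP(=O)(OC[C@@H]1C=C[C@H](n3cnc4c(N)ncnc43)O1)OC2` departs from compound 3 in one place: methyl in place of hydrogen on an aromatic carbon. This is methyl in place of hydrogen on an aromatic carbon. For the measured compounds named here, no two measured compounds differ in one place alone, so no measured step guides this change. The expectation therefore starts from compound 3 at 86000 nM, and no shift beyond the scatter is anticipated. The expected change is a 1.1-fold lower number from compound 3 to compound 4 (0.06 log units; within the scatter), an estimate that stays within the scatter. For compound 4 the expected value in this assay is 75000 nM, with an estimated range of 40000 nM to 130000 nM.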

Compound 4, half-maximal cytotoxic concentration: 49000 nM
Estimate against measurement, compound 4: 1.5-fold (0.18 log units) above; the range from low to high includes it.
By their numbers in this assay, from the lowest: compounds 4, 3 and 1 (each within the scatter of the next).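

In this assay, the step gives the series its first direct reading of a single change: methyl in place of hydrogen on an aromatic carbon amounts to a 1.8-fold lower number from compound 3 to compound 4 (0.24 log units; within the scatter). At this position, on a six-membered aromatic ring of carbon only, ortho to a fused ring and meta to a fused ring, adding methyl therefore produces no step beyond the scatter. A step of this size also has to be read against how far repeated entries for a single compound can spread: the several entries of compound 2 in this assay, 62000 nM; 40000 nM; 77000 nM (3 entries)

The compounds shown leave open whether another group on this same aromatic carbon, such as an amine, a carboxylic acid or a longer chain, would give a step beyond the scatter. They also leave open whether methyl would read the same way on the other aromatic carbons of this ring.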